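Swapping the urea aryl group in compound 4

The source may hold more compounds than are shown below. What is called first, only, known or untested is meant among the compounds shown, and "the series" means these compounds.

Compound 3 `COc1cc(-c2nn(-c3cccc(NC(=O)Nc4ccc(Cl)c(Cl)c4)c3)cc2-c2ccncc2)ccc1Cl` carries the higher of the two numbers in a functional assay on HOP-62 cells (Homo sapiens) for inhibition, read by sulforhodamine B assay, with a stated time of 48 h (a lower number here means a stronger inhibitor of growth, a higher number a weaker inhibitor of growth), giving 4900 nM, while compound 1 `COc1cc(-c2nn(-c3cccc(NC(=O)Nc4cc(C(F)(F)F)cc(C(F)(F)F)c4)c3)cc2-c2ccncc2)ccc1Cl` gives 1590 nM. Compound 2 `COc1cc(-c2nn(-c3cccc(NC(=O)c4cccc(C(F)(F)F)c4)c3)cc2-c2ccncc2)ccc1Cl` reaches only a limit in this assay, > 50000 nM; that limit is the limit of > 50000 nM in this assay, at which 1 of the 3 values shown sits. The step of an at least 10-fold lower number from compound 2 to compound 3 (1.00 log units; beyond the scatter) joins a change from amide to urea with a change of aryl group. Compound 4 `COc1cc(-c2nn(-c3cccc(NC(=O)Nc4cccc(C(F)(F)F)c4)c3)cc2-c2ccncc2)ccc1Cl` differs from compound 3 by 3-(trifluoromethyl)phenyl in place of 3,4-dichlorophenyl on an amide-type nitrogen. Among the compounds with values here, no measured step isolates this aryl swap within the urea pair; compounds 1 and 3 carry different aryl groups and stand apart by a gap beyond the scatter. The step of a 1.6-fold lower number from compound 3 to compound 4 (0.21 log units; within the scatter) is expected to stay near the scatter. The estimate for compound 4 is 3000 nM, between 1000 nM and 12000 nM.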

Compound 4, concentration for total growth inhibition: 4070 nM
Compound 4: the middle estimate sits 1.4-fold (0.13 log units) below what was measured; measured number inside the range.
By their numbers in this assay, from the lowest: compound 1; then compounds 4 and 3 (each within the scatter of the next). At a limit, above all of these: compound 2.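

In this assay, the aryl swap within the urea pair can now be read directly: a 1.2-fold lower number from compound 3 to compound 4 (0.08 log units; within the scatter) stays within the scatter, so 3,4-dichlorophenyl and 3-(trifluoromethyl)phenyl are not told apart at this place. The second trifluoromethyl does register, with a 2.6-fold higher number from compound 1 to compound 4 (0.41 log units; beyond the scatter). With the 3-(trifluoromethyl)phenyl group held constant, the urea in place of the amide gives an at least 12-fold lower number from compound 2 to compound 4 (1.08 log units; beyond the scatter), a step read from a limit: the limit of > 50000 nM in this assay, at which 1 of the 4 values shown sits.

What the compounds shown leave open is whether an aryl group carrying an amine or a carboxylic acid would shift the number. Also open, going by these compounds, is how a plain alkyl chain on the urea in place of the aryl group would read.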